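The compounds below may be only part of what the source reports. "The series", "measured", "known", "first", "only" and "open" are said of these compounds alone.

compound 1 `COc1ccc(/C=C\c2cc(OC)c(OC)c(OC)c2)cc1OCc1ccc(CO)cc1`: 37000 nM
compound 2 `COc1ccc(/C=C\c2cc(OC)c(OC)c(OC)c2)cc1OCc1ccc(CN2CC[C@@H](C(=O)O)C2)cc1`: 27000 nM

Both values come from an ADME assay on HEK293 cells (Homo sapiens) for cytotoxicity, read by CCK-8 assay, with a stated time of 48 h; a lower number here means a stronger inhibitor, a higher number a weaker inhibitor. Only these two compounds have been measured, and compound 2 lies within the scatter of compound 1 (a 1.4-fold lower number from compound 1 to compound 2 (0.14 log units; within the scatter)), so neither can be ranked over the other. Compound 3 `COc1ccc(/C=C\c2cc(OC)c(OC)c(OC)c2)cc1OCc1ccc(CN2CC[C@@H](O)C2)cc1` matches compound 2 except at one place, with hydroxy in place of carboxy on a saturated ring carbon. Among the compounds with values here, only one measured step bears on this change. It put the whole 3-carboxypyrrolidin-1-yl group in place of a hydroxy on a saturated chain carbon and stayed within the scatter (a 1.4-fold lower number from compound 1 to compound 2 (0.14 log units; within the scatter)). That step does not test the carboxy-to-hydroxy swap directly, so the range must stay wide, but no step beyond the scatter is expected in this assay. The expected change is small (a 1.1-fold lower number from compound 2 to compound 3 (0.03 log units; within the scatter)). The estimated value for compound 3 is 25000 nM (expected range 9000 nM to 60000 nM).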

Compound 3, half-maximal inhibitory concentration: > 50000 nM
Compound 3: no number, only a limit; the forecaster's own chance of this, stated with the estimate: 15%; at least 2.0-fold (0.30 log units) between middle value and limit.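

In this assay, compound 3 carries a limit of the assay and not a number: the limit of > 50000 nM in this assay, at which 1 of the 3 values shown sits. At this saturated ring carbon, the change from carboxy to hydroxy gives an at least 1.8-fold higher number from compound 2 to compound 3 (0.26 log units; that floor lies within the scatter), while the full exchange of the chain hydroxy for 3-hydroxypyrrolidin-1-yl gives an at least 1.3-fold higher number from compound 1 to compound 3 (0.13 log units; that floor lies within the scatter). Both floors lie within the scatter, so neither step is shown to exceed it, but the new result adds that hydroxy on this ring carbon brings no lower number, so the carboxy is not required for the number to stay this high.

As far as these compounds go, the true size of both steps stays unknown, as compound 3 has no exact value. From the compounds shown here alone, how a primary amine or a methoxy group on this ring carbon would behave also remains open.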